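Removing the chloro from the hydrazone compound 2

The compounds below may be only part of what the source reports. "The series", "measured", "known", "first", "only" and "open" are said of these compounds alone.

Compound 1 `COc1ccc(OC)c(/C=C/c2nnc(Nc3ccc(Cl)cc3)o2)c1` gives in a functional assay on A549 cells (Homo sapiens) for antiproliferative activity, read by sulforhodamine B assay, with a stated time of 48 h (on this read-out lower numbers stand for stronger inhibition of growth and higher numbers for weaker inhibition of growth), a concentration for total growth inhibition of 17800 nM. Compound 2 `COc1ccc(OC)c(/C=C/C(=O)N/N=C/c2ccc(Cl)cc2)c1`, the open-chain acylhydrazone analogue, is read in this assay only as a limit and not as a number: compound 2 gives > 100000 nM. Among the two values shown, compound 2 stands at the limit of > 100000 nM in this assay, at which 1 of the 2 values shown sits. Within the data shown here, no step between measured compounds can be drawn, since compound 1 and compound 2 differ in more than one place.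

Compound 3 `COc1ccc(OC)c(/C=C/C(=O)N/N=C/c2ccccc2)c1` differs from compound 2 by hydrogen in place of chloro on an aromatic carbon. Given that compound 2 sits at the limit, the step is expected to be a number no higher from compound 2 to compound 3 (the limit leaves the size open), with no change beyond the scatter anticipated in either direction. Compound 3 is therefore estimated at 100000 nM in this assay, within a range from 30000 nM to 300000 nM, and most probably reported again only as a limit.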

Compound 3, concentration for total growth inhibition: > 100000 nM
Compound 3: no number, only a limit; the forecaster's own chance of this, stated with the estimate: 70%; the middle value sits exactly at the limit.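

Compound 2 and compound 3 are both read only as limits, not as numbers, so no step between them can be read: the limit of > 100000 nM in this assay, at which 2 of the 3 values shown sit.

The compounds shown leave open what size of change, if any, going from 4-chlorophenyl to phenyl brings to the open-chain acylhydrazone.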